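The source may report more compounds than this note shows. Statements on the series, on what has been measured and on what is new or still open speak of the compounds shown alone.

Of the compounds shown here, two have so far been measured in a functional assay on HCT-116 cells (Homo sapiens) for inhibition, read by CCK-8 assay, with a stated time of 72 h, tested at 8 uM; a lower number here means less inhibition of growth, a higher number more inhibition of growth at the concentration tested. There, compound 1 `CCc1ccc(SCc2ccc(/C=C/C(=O)Nc3ccccc3N)cc2)cc1` gives 2.68%, while compound 2 `CCc1ccc(SCc2ccc(C(=O)Nc3ccccc3N)cc2)cc1` gives 79.1%, the higher of the two numbers and well beyond the scatter of compound 1. The next compound, compound 3 `CC(C)(C)c1ccc(SCc2ccc(C(=O)Nc3ccccc3N)cc2)cc1`, keeps the shared core of compound 2 but has tert-butyl in place of ethyl on an aromatic carbon, para to a large group (tert-butyl in place of ethyl on an aromatic carbon). Within the data shown here, no measured pair differing in one place shows what such a swap does, so the expectation rests only on compound 2 at 79.1% and on this single change. No step beyond the scatter is expected, and the estimated a number 7.1 percentage points lower from compound 2 to compound 3 (within the scatter) points slightly downward. For compound 3 the estimated value in this assay is 72%, with an expected range of 45% to 88%.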

Compound 3, percent growth inhibition at one concentration: 60.5%
For compound 3 the middle estimate is 11.5 percentage points above the measured one, within the range that was stated.
By their numbers in this assay, from the lowest: compound 1; then compound 3; then compound 2.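

Among these compounds, exchanging the ethyl group for tert-butyl, para to a large group, gives the first readable step at this position in this assay, a number 18.6 percentage points lower from compound 2 to compound 3 (beyond the scatter). The read-out therefore responds to the choice between these two alkyl groups, yet the change does not abolish growth inhibition, since compound 3 still gives 60.5%. Nothing measured on these compounds explains the step, so its cause stays unknown.

A single step cannot show whether the drop is particular to tert-butyl or would also appear with isopropyl, or whether methyl or a bare hydrogen at this position would compare differently with ethyl. The compounds shown also leave open how a group of another kind would fare here, such as an amine, a carboxylic acid or a methoxy group.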